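The source may hold more compounds than are shown below. What is called first, only, known or untested is meant among the compounds shown, and "the series" means these compounds.

Measured so far in a functional assay on A549 cells (Homo sapiens) for antiproliferative activity, read by MTT assay, with a stated time of 72 h; on this read-out higher numbers stand for weaker inhibition and lower numbers for stronger inhibition:
- compound 1 (`NC1=NC2(CCOCC2)N(OCCCOc2ccccc2)C(N)=N1`) gives 1080 nM
- compound 2 (`CC(C)(C)c1ccc(OCCCON2C(N)=NC(N)=NC23CCSCC3)cc1`) gives 1 nM
- compound 3 (`NC1=NC2(CCSCC2)N(OCCCOc2cccc(Cl)c2)C(N)=N1`) gives 60 nM

Compound 1 carries the highest number of the three and is therefore the weakest inhibitor here. Compound 3 lies nearest to it and compound 2 furthest from it, both beyond the usual scatter. No two of these compounds differ in one place only, so none of the gaps can be assigned to a single change.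

Compound 4 (`NC1=NC2(CCOCC2)N(OCCCOc2ccc(F)cc2)C(N)=N1`) has not yet been measured. It keeps the core of compound 1 and turns phenoxy into 4-fluorophenoxy, with fluoro in place of hydrogen on an aromatic carbon, para to a large group (fluoro in place of hydrogen on an aromatic carbon). The guidance available is loose. Compound 2 and compound 3 also carry a substituent on the aromatic ring of the phenoxy group, and compound 3 reads 60 nM on a different core, so only part of that gap can be expected to carry over. A small move towards stronger inhibition is therefore expected, near the edge of the scatter, and the estimated step is a 2.2-fold lower number from compound 1 to compound 4 (0.33 log units; beyond the scatter) in this assay. For compound 4 the estimated value is 500 nM, with an expected range from 130 nM to 1700 nM.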

Compound 4, half-maximal inhibitory concentration: 1060 nM
Compound 4: middle estimate off by 2.1-fold (0.33 log units), on the low side; the range from low to high includes it.
By their numbers in this assay, from the lowest: compound 2; then compound 3; then compounds 4 and 1 (each within the scatter of the next).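

In this assay, fluoro in place of hydrogen on an aromatic carbon, para to a large group, gives a 1.0-fold lower number from compound 1 to compound 4 (0.01 log units; within the scatter), which lies within the scatter. This is the only step shown between compounds that differ in one place, and it indicates that, on the core of compound 1, phenoxy and 4-fluorophenoxy cannot be told apart in this read-out. Compound 2 and compound 3 each differ from compound 1 in more than one place, so the substituted rings of those compounds gave no such reading, and no measurement at hand offers an explanation for this result.

The compounds shown leave open whether a methoxy group, an amine or a carboxylic acid at this same place would read differently from fluoro on this core, and whether fluoro would also leave the number unmoved on the core of compound 2 or compound 3. They also do not separate how much of the gaps from compound 1 to compound 2 and compound 3 belongs to the core and how much to the substituent on the aromatic ring.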